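Cytotoxicity Limits Across Three Close Analogues

The source may report more compounds than this note shows. Statements on the series, on what has been measured and on what is new or still open speak of the compounds shown alone.

Compound 1 `Cc1nnc(SCC(=O)c2ccc(Cl)cc2)n1N1C(=O)c2ccccc2C1=O` — in a functional assay on A549 cells (Homo sapiens) for cytotoxicity, read by MTT assay, with a stated time of 48 h (on this read-out higher numbers stand for weaker inhibition and lower numbers for stronger inhibition), compound 1 reaches only the assay limit > 200000 nM.
Compound 2 `Cc1ccc(C(=O)CSc2nnc(C)n2N2C(=O)c3ccccc3C2=O)cc1` — in this assay compound 2 reaches only the assay limit > 200000 nM.
Compound 3 `CCc1nnc(SCC(=O)c2ccc(Cl)cc2)n1N1C(=O)c2ccccc2C1=O` — in this assay compound 3 reaches only the assay limit > 200000 nM.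

For the measured compounds named here, every value here is a limit, not a number, so no step between the measured compounds can be sized. The change from compound 1 to compound 2 is methyl in place of chloro on an aromatic carbon, and the result is a step that the two limits leave unreadable from compound 1 to compound 2. The two cores differ by methyl in place of hydrogen on a saturated chain carbon bound to an aromatic carbon, and that step reads a step that the two limits leave unreadable from compound 1 to compound 3.

Compound 4 `CCc1nnc(SCC(=O)c2ccc(C)cc2)n1N1C(=O)c2ccccc2C1=O` has not been measured in this assay. Going by the values given here, it differs from compound 3 by methyl in place of chloro on an aromatic carbon, which is the same change as the one from compound 1 to compound 2, at the same place word for word. Because (the limit of > 200000 nM in this assay, at which 3 of the 3 values shown sit), nothing in the set points to a readable number for compound 4. Compound 4 is therefore expected to give about 300000 nM, between 150000 nM and 1000000 nM. The step this estimate means is a step that the limit leaves unreadable from compound 3 to compound 4, which rests on (the limit of > 200000 nM in this assay, at which 3 of the 3 values shown sit).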

Compound 4, half-maximal inhibitory concentration: > 200000 nM
Compound 4: a limit, no number; the forecaster's own chance of this, stated with the estimate: 90%; the middle value is on the limit's open side.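

In this assay compound 4 gives > 200000 nM, which is a limit and not a number. The steps from compound 3 and from compound 2 to compound 4 cannot be read, because all the values are limits: the limit of > 200000 nM in this assay, at which 4 of the 4 values shown sit. The compounds shown leave open what concentration, if any, gives half-maximal inhibition, and whether either change alters it.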